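Exchanging the Amide Side Chain of Compound 2

The compounds below may be only part of what the source reports. "The series", "measured", "known", "first", "only" and "open" are said of these compounds alone.

In a functional assay on PC-3 cells (Homo sapiens) for antiproliferative activity, read by MTT assay, with a stated time of 72 h (a lower number here means a stronger inhibitor, a higher number a weaker inhibitor), compound 1 (`CCn1c(C(=O)N[C@H](C(=O)O)C(C)C)ccc1C(CC)(CC)c1ccc(C#CC(O)(CC)CC)c(C)c1`) gives 5000 nM and compound 2 (`CCn1cc(C(CC)(CC)c2ccc(C#CC(O)(CC)CC)c(C)c2)cc1C(=O)NCCCN(C)C`) gives 15100 nM as the higher of the two numbers, a gap beyond the scatter. Compound 3 (`CCn1cc(C(CC)(CC)c2ccc(C#CC(O)(CC)CC)c(C)c2)cc1C(=O)N[C@@H](C)CO`) alters compound 2 at one place, with 1-(hydroxymethyl)ethyl in place of 3-(dimethylamino)propyl on an amide-type nitrogen. Going by the values given here, no measured pair differs in one place only, so the size of this exchange has no direct precedent in these data. Among the compounds with values here, the only lower reference is compound 1 at 5000 nM in this assay, and it differs from compound 2 in more than the amide group. Only a small move toward a lower number is therefore expected, estimated as a 1.5-fold lower number from compound 2 to compound 3 (0.18 log units; within the scatter) and not beyond the scatter. For compound 3 the estimate is 10000 nM with an expected range from 4000 nM to 25000 nM in this assay.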

Compound 3, half-maximal inhibitory concentration: 6050 nM
For compound 3 the middle estimate is 1.7-fold (0.22 log units) above the measured one, within the range that was stated.
By their numbers in this assay, from the lowest: compounds 1 and 3 (each within the scatter of the next); then compound 2.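

In this assay putting 1-(hydroxymethyl)ethyl in place of 3-(dimethylamino)propyl on the amide-type nitrogen gives a 2.5-fold lower number from compound 2 to compound 3 (0.40 log units; beyond the scatter) and so provides the only single-place step shown, a modest one that shows the read-out responds to the group at this position while the rest of compound 2 stays unchanged. The exchange alters several things at once: the chain loses its nitrogen, and the entering group is smaller, adds a hydrogen-bond donor and carries a defined stereocentre. No measurement here bears on what lies behind the step.

On these data alone, whether the hydroxyl group, the shorter chain or the loss of the dimethylamino group carries the step remains open, and a plain propyl chain or a 3-hydroxypropyl chain on this nitrogen would bear on that. Also open, as far as these compounds go, are the mirror-image form of the 1-(hydroxymethyl)ethyl group and a carboxylic acid on this side chain.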